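Fluoro Gives Way to Acetyl on the Pendant Phenyl Ring

This account rests on a few compounds, and the source may have more. Where it says the series, first, only, none or still open, it means among the compounds named here.

Measured compounds in a functional assay on SGC-7901 cells (Homo sapiens) for antiproliferative activity, read by MTT assay, with a stated time of 72 h; on this read-out higher numbers stand for weaker inhibition and lower numbers for stronger inhibition:
Compound 1, `COc1ccc(-c2ccc3ncn(-c4cc(OC)c(OC)c(OC)c4)c3c2)cc1`: 82 nM
Compound 2, `COc1cc(-n2cnc3ccc(-c4ccc(Cl)cc4Cl)cc32)cc(OC)c1OC`: > 10000 nM
Compound 3, `COc1cc(-n2cnc3ccc(-c4ccc(F)cc4)cc32)cc(OC)c1OC`: 3500 nM

Compound 3 carries the highest of the two numbers actually shown; its nearest neighbour is compound 1, and a 43-fold higher number from compound 1 to compound 3 (1.63 log units; beyond the scatter). For compound 2 the assay returns only a limit, (the limit of > 10000 nM in this assay, at which 1 of the 3 values shown sits). Set against that limit, an at least 2.8-fold lower number from compound 2 to compound 3 (0.45 log units; beyond the scatter).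

Compound 4, `COc1cc(-n2cnc3ccc(-c4ccc(C(C)=O)cc4)cc32)cc(OC)c1OC`, differs from compound 3 in one place: acetyl in place of fluoro on an aromatic carbon. Among the measured compounds shown here, two measured steps bear on it. The step of a 43-fold higher number from compound 1 to compound 3 (1.63 log units; beyond the scatter) shows that the group on this aromatic carbon of the 4-substituted phenyl moves the number strongly, a methoxy sitting far below a fluoro. The step of an at least 120-fold higher number from compound 1 to compound 2 (2.08 log units; beyond the scatter) shows that a 2,4-dichlorophenyl fares worse still. Acetyl, like methoxy, brings an oxygen acceptor to this carbon, so a modest lowering of the number for compound 4 is expected, a 2.3-fold lower number from compound 3 to compound 4 (0.37 log units; beyond the scatter). Compound 4 is therefore estimated at 1500 nM, with a range from 300 nM to 8000 nM.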

Compound 4, half-maximal inhibitory concentration: 450 nM
Compound 4: the middle estimate sits 3.3-fold (0.52 log units) above what was measured; the measured number falls inside the stated range.
By their numbers in this assay, from the lowest: compound 1; then compound 4; then compound 3. At a limit, above all of these: compound 2.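

Among the compounds shown here, at this carbon, para to a large group, the earlier compounds showed only how far fluoro falls short of methoxy; acetyl now fills part of that gap in this assay (a 7.8-fold lower number from compound 3 to compound 4 (0.89 log units; beyond the scatter)). It still does not match methoxy (a 5.5-fold higher number from compound 1 to compound 4 (0.74 log units; beyond the scatter)), so among these three compounds the order runs methoxy, acetyl, fluoro. Compound 2 stands at a limit of the assay, which makes its step to 4-acetylphenyl a bound and not a measured size (an at least 22-fold lower number from compound 2 to compound 4 (1.34 log units; beyond the scatter)): (the limit of > 10000 nM in this assay, at which 1 of the 4 values shown sits).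

Going by these compounds, whether an amine, a hydroxyl or a carboxylic acid on this carbon would fall nearer methoxy or nearer fluoro remains open. So does whether a longer chain on the carbonyl would keep or lose what acetyl gains over fluoro.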